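The compounds below may be only part of what the source reports. "The series", "measured", "known", "first", "only" and "open" are said of these compounds alone.

Working notes on the series. Two compounds carry numbers in an ADME assay on BJ cells (Homo sapiens), read by MTT assay, with a stated time of 72 h (a higher number here means a weaker inhibitor, a lower number a stronger inhibitor), so far. Compound 1, `C#Cc1cn([C@@H]2O[C@H](CO)[C@@H](O)[C@H]2O)c2ncnc(N(C)C)c12`, gives 410 nM in this assay. Among the measured compounds shown here, compound 2, `CNc1ncnc2c1c(-c1ccco1)cn2[C@@H]1O[C@H](CO)[C@@H](O)[C@H]1O`, gives 5040 nM in this assay, the higher of the two numbers; the gap between compound 1 and compound 2 lies beyond the scatter, but the two structures differ in more than one place, so no single step is set out between them and only the two values themselves can be read.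

Compound 3, `C#Cc1cn([C@@H]2O[C@H](CO)[C@@H](O)[C@H]2O)c2ncnc(NC)c12`, is not yet measured in this assay. Relative to compound 2 the change is ethynyl in place of furan-2-yl on an aromatic carbon. For the measured compounds named here, the group entering is the one compound 1 carries at the same place, and compound 1 gives 410 nM, while compound 3 keeps the amine of compound 2. Going by the values given here, with no isolated step to lean on, the expectation is a drop, most likely beyond the scatter, so that a 6.3-fold lower number from compound 2 to compound 3 (0.80 log units; beyond the scatter) is estimated for compound 3 in this assay. Compound 3 is expected to give about 800 nM, within a range of 250 nM to 3000 nM, pending the measurement.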

Compound 3, half-maximal inhibitory concentration: 86000 nM
Compound 3: middle estimate off by 110-fold (2.03 log units), on the low side; measured number outside the range, above it.
By their numbers in this assay, from the lowest: compound 1; then compound 2; then compound 3.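

The new compound shows that the aromatic carbon bearing furan-2-yl or ethynyl is sensitive to the group placed there: with the methylamino group held constant in this assay, ethynyl in place of furan-2-yl gives a 17-fold higher number from compound 2 to compound 3 (1.23 log units; beyond the scatter), a large step beyond the scatter. Among the compounds shown here, it also shows that ethynyl alone does not secure a low number, since with ethynyl held constant, hydrogen in place of methyl on the nitrogen gives a 210-fold higher number from compound 1 to compound 3 (2.32 log units; beyond the scatter) and leaves compound 3 with the highest number of the series so far. No supporting measurement is available to account for either step.

The compounds shown leave open how furan-2-yl reads when the nitrogen carries two methyl groups, so it remains unknown whether the effects at the two places are independent or whether the preferred group on the aromatic carbon depends on the substitution of the nitrogen. Also open, from the compounds shown here alone, is how a phenyl ring or a longer alkyne chain on that aromatic carbon, or an unsubstituted amine on the nitrogen, would read in this assay.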